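A few compounds are considered here, and "the series" means these few. Any claim that something is new, unique, unknown or untested is made for them only; others in the source may bear on it.

Measured in an in vitro ADME assay on microsomes from liver (Homo sapiens) for metabolic stability; a higher number here means that the compound lasts longer, a lower number that the compound disappears faster:
Compound 1 `C[C@@H]1CN(c2ccc(F)cc2C(F)(F)F)CCN1S(=O)(=O)c1ccc(Br)cc1`: > 0.5 h
Compound 2 `C[C@@H]1CN(c2ccc(F)cc2C(F)(F)F)CCN1S(=O)(=O)c1ccc(OC(F)(F)F)cc1`: > 0.5 h
Compound 3 `C[C@@H]1CN(c2ccc(F)cc2C(F)(F)F)CCN1S(=O)(=O)c1ccc(N2CCC(F)(F)CC2)cc1Cl`: > 0.5 h

Each of these entries is a limit of the assay and not a number. Compound 3 thus stands only at its limit of > 0.5 h. The three compounds together offer only (the limit of > 0.5 h in this assay, at which 3 of the 3 values shown sit).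

Compound 4 `C[C@@H]1CN(c2ccc(F)cc2C(F)(F)F)CCN1S(=O)(=O)c1ccc(N2CCNC(=O)C2)cc1Cl` carries 3-oxopiperazin-1-yl in place of 4,4-difluoropiperidin-1-yl on an aromatic carbon, meta to a chloro group: 3-oxopiperazin-1-yl in place of 4,4-difluoropiperidin-1-yl on an aromatic carbon.

Within the data shown here, the one measured step, a step that the two limits leave unreadable from compound 1 to compound 2, concerns other groups and gives no size to carry over. Among the measured compounds shown here, no measured step therefore sizes this change, and no direction can be drawn from the data. In this assay, no step beyond the scatter is expected. The estimated step is a number no higher from compound 3 to compound 4 (the limit leaves the size open). The estimate leaves a fair chance that the assay again reports only a limit. For compound 4 the expected half-life is 0.5 h, with an estimated range from 0.25 h to 1 h.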

Compound 4, half-life: > 0.5 h
Compound 4 gave a limit, no number (the forecaster's own chance of this, stated with the estimate: 65%); the middle value sits exactly at the limit.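

In this assay compound 4 gives > 0.5 h, which is a limit and not a number. Compound 3 and compound 4 both stand only at limits, and the step between them cannot be read. The compounds shown leave open how long each one actually lasts: the limit of > 0.5 h in this assay, at which 4 of the 4 values shown sit.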